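Methoxy for Fluoro on Two Related Cores

The compounds below may be only part of what the source reports. "The series", "measured", "known", "first", "only" and "open" are said of these compounds alone.

Compound 1 `Cn1c(-c2cc(-c3ccc(F)cc3)no2)cc2ccccc21` and compound 2 `Fc1ccc(-c2cc(-c3ccc4[nH]ccc4c3)on2)cc1` both carry a fluoro group on an aromatic carbon; how their two cores differ is not broken down here. In a functional assay on Calu-3 cells (Homo sapiens) for cytotoxicity, read by WST assay, with a stated time of 72 h (a lower number here means a stronger inhibitor, a higher number a weaker inhibitor), compound 2 gives 16800 nM. For compound 1 this assay reports only a limit, > 100000 nM. Compound 3 `COc1ccc(-c2cc(-c3cc4ccccc4n3C)on2)cc1` arises from compound 1 by methoxy in place of fluoro on an aromatic carbon. For compound 3 this assay again reports only a limit, > 100000 nM. The step that the two limits leave unreadable from compound 1 to compound 3 thus cannot be read, since the limit of > 100000 nM in this assay, at which 2 of the 3 values shown sit, holds both of its ends.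

Compound 4 `COc1ccc(-c2cc(-c3ccc4[nH]ccc4c3)on2)cc1` arises from compound 2 by the same change, (methoxy in place of fluoro on an aromatic carbon). Compound 4 is expected to give about 20000 nM. The expected step of a 1.2-fold higher number from compound 2 to compound 4 (0.08 log units; within the scatter) is small, resting on compound 2 at 16800 nM and on the unreadable step that the two limits leave unreadable from compound 1 to compound 3, which gives no ground for a larger change.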

Compound 4, half-maximal inhibitory concentration: 22500 nM
Compound 4: the middle estimate sits 1.1-fold (0.05 log units) below what was measured; the measured number falls inside the stated range.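

In this assay, putting methoxy in place of fluoro on the core of compound 2 gives a 1.3-fold higher number from compound 2 to compound 4 (0.13 log units; within the scatter), so on this core the swap makes no difference beyond the usual scatter. Compound 1 and compound 3 each carry only a limit and not a number, so the same swap on their core cannot be read: the limit of > 100000 nM in this assay, at which 2 of the 4 values shown sit. The series therefore offers one readable case, which does not show whether the swap behaves alike on both cores.

Still open, on these data alone, is how other groups would read on that same aromatic carbon, such as an amine or a carboxylic acid. With only fluoro and methoxy shown there, nothing can be said about groups of a different kind.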